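Working notes: from compound 2 to compound 4

The source may report more compounds than this note shows. Statements on the series, on what has been measured and on what is new or still open speak of the compounds shown alone.

Three compounds have numbers in an assay on HEK293 cells for agonist activity at transient receptor potential cation channel subfamily M member 8 (Homo sapiens), read by fluorescence and calcium flux, with a stated time of 15 min; on this read-out lower numbers stand for an effect already at smaller amounts and higher numbers for an effect only at larger amounts of compound. Compound 2 `CCN(Cc1cccs1)C(=O)COc1ccc(C(F)(F)F)cc1` gives 236 nM, the lowest of the three. Compound 1 `Cc1ccc(OCC(=O)N(Cc2cccs2)c2ccn(C)n2)cc1` gives 855 nM, a higher number than compound 2 and beyond the scatter; compound 3 `CCN(Cc1cccs1)C(=O)c1cc2cc(C)ccc2s1` gives 1600 nM, the highest of the three, also beyond the scatter from compound 2. For the measured compounds named here, no two of these differ in one place only, so no single step has been measured within the set.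

Compound 4 `CCN(Cc1cccs1)C(=O)COc1ccccc1` has not been measured. It differs from compound 2 by hydrogen in place of trifluoromethyl on an aromatic carbon, para to a large group. With no measured step of this kind in the series, the expectation rests on compound 2 alone, whose value 236 nM sets the starting point. A moderate rise in the number, beyond the scatter, is expected, so that the estimated step is a 3.0-fold higher number from compound 2 to compound 4 (0.47 log units; beyond the scatter). Compound 4 is estimated at 700 nM, with a range from 250 nM to 2500 nM.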

Compound 4, half-maximal effective concentration: 1400 nM
For compound 4 the middle estimate is 2.0-fold (0.30 log units) below the measured one; the range from low to high includes it.
By their numbers in this assay, from the lowest: compound 2; then compounds 1, 4 and 3 (each within the scatter of the next).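

In this assay, hydrogen in place of trifluoromethyl on an aromatic carbon, para to a large group, gives a 5.9-fold higher number from compound 2 to compound 4 (0.77 log units; beyond the scatter). For the compounds shown here, this is the only single-place step available, and it shows that, with the rest of the structure held constant, the group at this position alone moves the number beyond the scatter, which the three earlier compounds could not separate from their other differences. Nothing available accounts for the size of this step.

On these data alone, only trifluoromethyl and hydrogen can be compared at this position on this core, so the effect of a nitrile, a methoxy group, a chlorine atom or a carboxylic acid there remains open. As far as these compounds go, whether the step carries over to the cores of compound 1 and compound 3 also remains open.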